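Shortening the aryl ether: from compound 2 to compound 3

The compounds below may be only part of what the source reports. "The series", "measured", "known", "first", "only" and "open" are said of these compounds alone.

Two compounds measured in a functional assay on CHO cells for positive allosteric modulation of metabotropic glutamate receptor 2 (Homo sapiens), read by scintillation counting and GTPgammaS binding, with a stated time of 30 min (a lower number here means a smaller maximal response, a higher number a larger maximal response), share one core and differ only in the group hanging on an oxygen at the far end of the molecule. Compound 1 `CC(C)CCn1ccc(-c2ccc(Oc3ccccc3)cc2)c(C#N)c1=O` carries a phenyl there and gives 188%. Compound 2 `CC(C)CCn1ccc(-c2ccc(Oc3cccnc3)cc2)c(C#N)c1=O` carries a pyridin-3-yl instead and gives 231%, which is the higher of the two numbers, the step being a number 43 percentage points higher from compound 1 to compound 2 (beyond the scatter).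

Compound 3 `CNc1ccc(-c2ccn(CCC(C)C)c(=O)c2C#N)cc1` drops the ether altogether: methylamino in place of (pyridin-3-yl)oxy on an aromatic carbon. Among the compounds with values here, the only measured step swapped one ring for another on the oxygen and raised the response; no step shows what happens when the (pyridin-3-yl)oxy is removed and a much smaller methylamino takes its place on that aromatic carbon. Since the ring on the oxygen seemed to matter in that one step, a loss of response is expected, though its size is uncertain. The estimate for compound 3 is 150%, with a range from 95% to 215%, meaning an expected step of a number 81 percentage points lower from compound 2 to compound 3 (beyond the scatter).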

Compound 3, largest response reached (Emax), in percent of the reference or control that the assay uses: 186%
Estimate against measurement, compound 3: 36 percentage points below, and the stated range covers the measured number.
By their numbers in this assay, from the lowest: compounds 3 and 1 (each within the scatter of the next); then compound 2.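

In this assay, a large maximal response does not depend on an aryl ether at this position: compound 3 gives 186% with methylamino on that aromatic carbon, a group with no ring and no oxygen. The cost of removing the (pyridin-3-yl)oxy is real, with a number 45 percentage points lower from compound 2 to compound 3 (beyond the scatter) for this change, but the comparison with phenoxy reads differently, with a number 2 percentage points lower from compound 1 to compound 3 (within the scatter) for that swap, so among these three compounds only the pyridin-3-yl ether stands clear of the others, while phenoxy and methylamino cannot be told apart. No measurement at hand explains why these groups give these numbers.

The compounds shown leave open whether the response at this position follows any trend with group size, since a plain hydrogen, a methoxy, a dimethylamino or a longer amine such as ethylamino would each test a different part of the change from the ether to methylamino. They also leave open whether the higher response of compound 2 belongs to the ring nitrogen in that exact place, which a pyridin-2-yl or pyridin-4-yl on the oxygen would help to settle.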